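The source may hold more compounds than are shown below. What is called first, only, known or untested is meant among the compounds shown, and "the series" means these compounds.

Compound 1 `O=C(Nc1cccc(-c2oc3cc(-c4ccc(F)cc4)ccc3c(=O)c2O)c1)c1ccccc1F` gives 5630 nM in a functional assay on HeLa cells (Homo sapiens) for antiproliferative activity, read by CCK-8 assay, with a stated time of 72 h; on this read-out lower numbers stand for stronger inhibition and higher numbers for weaker inhibition; compound 2 `O=C(Nc1cccc(-c2oc3cc(-c4ccc(F)cc4)ccc3c(=O)c2O)c1)c1ccc(F)cc1` gives 5350 nM.

Compound 2 holds the lowest of the two numbers in this assay, yet compound 1 sits close: a 1.1-fold lower number from compound 1 to compound 2 (0.02 log units; within the scatter). Compound 3 `COc1ccc(C(=O)Nc2cccc(-c3oc4cc(-c5ccc(F)cc5)ccc4c(=O)c3O)c2)cc1` differs from compound 2 by methoxy in place of fluoro on an aromatic carbon, placed para to a large group. Within the data shown here, the only measured step, from compound 1 to compound 2, concerned the fluorine's ring position and stayed within the scatter, so no step beyond the scatter is expected here. The estimated step from compound 2 to compound 3 is therefore a 1.1-fold lower number from compound 2 to compound 3 (0.03 log units; within the scatter). For compound 3 the expected value is 5000 nM, within 2000 nM to 14000 nM.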

Compound 3, half-maximal inhibitory concentration: 4820 nM
Estimate against measurement, compound 3: 1.0-fold (0.02 log units) above; the measured number falls inside the stated range.
By their numbers in this assay, from the lowest: compounds 3, 2 and 1 (each within the scatter of the next).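

Methoxy in place of fluoro on an aromatic carbon, para to a large group, gives a 1.1-fold lower number from compound 2 to compound 3 (0.05 log units; within the scatter) in this assay, so changing the group itself, and not only the fluorine's ring position, leaves the number within the scatter. The wider change, 4-methoxyphenyl in place of 2-fluorophenyl, gives a 1.2-fold lower number from compound 1 to compound 3 (0.07 log units; within the scatter), also within the scatter. No evidence here accounts for this result.

From the compounds shown here alone, whether an amine, a carboxylic acid or a longer alkoxy chain at this position would move the number beyond the scatter stays open. The steps shown do not yet tell whether this position can shift the number in either direction.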